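Compound 3: a (2-hydroxyethyl)carbamoyl group takes over

The compounds below may be only part of what the source reports. "The series", "measured", "known", "first", "only" and "open" are said of these compounds alone.

Compound 1 `O=C(Nc1cccc(Nc2ncc(F)c(Nc3ccc(F)cc3)n2)c1)c1ccccc1` gives > 10000 nM (a limit)
Compound 2 `CN(C)CC(=O)Nc1cccc(Nc2ncc(F)c(Nc3ccc(F)cc3)n2)c1` gives 1810 nM (a number)

Both compounds were tested in a functional assay on KBVIN cells (Homo sapiens) for antiproliferative activity, read by sulforhodamine B assay, with a stated time of 3 days (on this read-out higher numbers stand for weaker inhibition of growth and lower numbers for stronger inhibition of growth), and the entry for compound 1 is a limit of the assay, not a number. Among the compounds with values here, compound 2 therefore holds the only true number so far, and no further values exist to place it against.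

Compound 3 `O=C(NCCO)c1cccc(Nc2ncc(F)c(Nc3ccc(F)cc3)n2)c1` has not yet been measured. Its difference from compound 2 is (2-hydroxyethyl)carbamoyl in place of (((dimethylamino)methyl)carbonyl)amino on an aromatic carbon and in words it is (2-hydroxyethyl)carbamoyl in place of (((dimethylamino)methyl)carbonyl)amino on an aromatic carbon.

Within the data shown here, only one measured step bears on this change. It is an at least 5.5-fold lower number from compound 1 to compound 2 (0.74 log units; beyond the scatter) and it came with (dimethylamino)methyl in place of phenyl on a carbonyl carbon. Compound 3 no longer carries that (dimethylamino)methyl, so part of that gain is expected to be lost, though one step is thin support.

The expected step is a 2.5-fold higher number from compound 2 to compound 3 (0.40 log units; beyond the scatter) in this assay toward weaker inhibition of growth. Compound 3 is estimated at 4500 nM with an expected range from 1800 nM to 10000 nM as its span.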

Compound 3, concentration for 50% growth inhibition: 21400 nM
For compound 3 the middle estimate is 4.8-fold (0.68 log units) below the measured one; measured number above the stated range.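

In this assay, (2-hydroxyethyl)carbamoyl in place of (((dimethylamino)methyl)carbonyl)amino, on an aromatic carbon meta to a large group, gives a 12-fold higher number from compound 2 to compound 3 (1.07 log units; beyond the scatter). The earlier pair differed only in what sits on the carbonyl carbon, whereas here the whole group is exchanged, and the large step comes with a change that leaves some computed features alike: neither group has a ring or a net charge, and each has one double bond outside aromatic rings. The step from compound 1 to compound 3 cannot be read because the entry for compound 1 is a limit and not a number: the limit of > 10000 nM in this assay, at which 1 of the 3 values shown sits.

The compounds shown leave open which part of the exchange goes with the step, since the dimethylamino group is lost, a hydroxyl enters and the amide changes its direction on the ring, all in one move. A (2-(dimethylamino)ethyl)carbamoyl group or a (hydroxyacetyl)amino group at this place would separate these changes, and a carboxylic acid or a longer chain would show how far the trend at this position extends.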